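Caffeic and ferulic amides: from alanine to isoleucine ester

A few compounds are considered here, and "the series" means these few. Any claim that something is new, unique, unknown or untested is made for them only; others in the source may bear on it.

Measured so far:
compound 1, `CCOC(=O)[C@@H](NC(=O)/C=C/c1ccc(O)c(OC)c1)C(C)C`: 59600 nM
compound 2, `CCOC(=O)[C@H](C)NC(=O)/C=C/c1ccc(O)c(O)c1`: 29700 nM
compound 3, `COc1cc(/C=C/C(=O)O)ccc1OC(C)=O`: > 500000 nM

Three compounds have been run in a functional assay, read by spectrophotometry, with a stated time of 30 min; a higher number here means a weaker inhibitor, a lower number a stronger inhibitor. Compound 2 gives 29700 nM in this assay, and compound 1 gives 59600 nM; the two numbers lie within the usual scatter of one another, so compound 2 cannot be separated from compound 1 on these data. Compound 3 gives a limit in this assay, > 500000 nM, and not a number: the limit of > 500000 nM in this assay, at which 1 of the 3 values shown sits. For the measured compounds named here, compound 3 is the one compound here without an amino ester on the amide side and with the phenol carrying an acetyl group.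

No two of the measured compounds differ in a single place, so no measured step can be read off directly. The comparison of compound 2 with compound 1 does suggest that a larger branched side chain on the carbon bound to the amide-type nitrogen and the carbonyl carbon does not move the number far, though compound 1 also differs from compound 2 on the aryl ring.

Compound 4, `CCOC(=O)[C@@H](NC(=O)/C=C/c1ccc(O)c(O)c1)[C@@H](C)CC`, has not yet been measured in this assay. Compared with compound 2 it carries sec-butyl in place of methyl on a saturated chain carbon bound to an amide-type nitrogen and a carbonyl carbon.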

Compound 4, half-maximal inhibitory concentration: 43500 nM
Compound 4: middle estimate off by 1.5-fold (0.16 log units), on the low side; the measured number falls inside the stated range.
By their numbers in this assay, from the lowest: compounds 2, 4 and 1 (each within the scatter of the next). At a limit, above all of these: compound 3.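

In this assay, the change from methyl to sec-butyl on a saturated chain carbon bound to an amide-type nitrogen and a carbonyl carbon can now be read on its own: a 1.5-fold higher number from compound 2 to compound 4 (0.17 log units; within the scatter). The earlier comparison of compound 2 with compound 1 could only hint at this, since those two also differ on the aryl ring, whereas here the rest of the molecule stays the same and the larger branched group leaves the number within the scatter, so this position accepts both methyl and sec-butyl without a separable difference in this assay. Nothing among the data shown gives a cause for this step.

The compounds shown leave open whether this tolerance extends to groups of another kind at the same carbon, such as a benzyl group, a hydroxymethyl group or a chain ending in an amine, since only hydrocarbon side chains appear here. From the compounds shown here alone, it also remains open how this assay would respond to a free carboxylic acid in place of the ethyl ester, with the side chain kept as sec-butyl.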